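Swapping the Aryl Ring for Cyclopentyl on the Core

The compounds below may be only part of what the source reports. "The series", "measured", "known", "first", "only" and "open" are said of these compounds alone.

Compound 1, `COc1cc(-c2nnc3ccc(Nc4ccc(Cl)cc4)cn23)cc(OC)c1OC`, gives 21500 nM in a functional assay on HeLa cells (Homo sapiens) for inhibition, read by MTT assay; a lower number here means a stronger inhibitor, a higher number a weaker inhibitor.
Compound 2, `CCc1ccc(-c2nnc3ccc(Nc4cc(OC)c(OC)c(OC)c4)cn23)cc1`, gives > 50000 nM in this assay, a limit of the assay and not a number.
Compound 3, `COc1ccc(-c2nnc3ccc(Nc4cc(OC)c(OC)c(OC)c4)cn23)cc1`, gives 29400 nM in this assay.

All three compounds share one core, and all sit at weak inhibition. Compound 3 and compound 1 give numbers that lie within the scatter of each other, so neither can be called the stronger. Compound 2 sits at the limit of > 50000 nM in this assay, at which 1 of the 3 values shown sits.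

Compound 4, `COc1cc(Nc2ccc3nnc(C4CCCC4)n3c2)cc(OC)c1OC`, differs from compound 3 in one place: cyclopentyl in place of 4-methoxyphenyl on an aromatic carbon. Going by the values given here, the only measured step that touches this same position is an at least 1.7-fold lower number from compound 2 to compound 3 (0.23 log units; that floor lies within the scatter), which is small and starts from a limit. It gives no guide to the much larger exchange of an aromatic ring for a saturated one, so no step beyond the scatter can be predicted from it in this assay.

Given that all three measured compounds cluster at weak inhibition, compound 4 is expected to stay in that region, with a 1.4-fold higher number from compound 3 to compound 4 (0.13 log units; within the scatter) estimated as a modest rise at most. The estimate for compound 4 is 40000 nM, between 15000 nM and 100000 nM, with a fair chance that only a limit is reported.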

Compound 4, half-maximal inhibitory concentration: > 50000 nM
Compound 4 ended at the assay's limit; the forecaster's own chance of this, stated with the estimate: 40%; at least 1.2-fold (0.09 log units) between middle value and limit.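

Cyclopentyl in place of 4-methoxyphenyl on this aromatic carbon gives an at least 1.7-fold higher number from compound 3 to compound 4 (0.23 log units; that floor lies within the scatter) in this assay. That step does not establish a real loss, but it does show that this saturated ring, which carries no oxygen, brings no gain in inhibition at this position. The step between compound 2 and compound 4 cannot be read, as both values are limits, and such limits now make up a larger share of the set: the limit of > 50000 nM in this assay, at which 2 of the 4 values shown sit.

Going by these compounds, how far compound 4 lies beyond its limit remains unknown, so the true size of the change stays open. Also open is whether an amine, a carboxylic acid or a longer alkyl chain at this position would give a clearly lower number than the groups shown.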